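Trifluoromethyl for nitro on the anilino ring of compound 3

The compounds below may be only part of what the source reports. "The series", "measured", "known", "first", "only" and "open" are said of these compounds alone.

Measured compounds:
compound 1 `FC(F)(F)c1ccc(CSc2nc(Nc3cccc(C(F)(F)F)c3)c3ccccc3n2)cc1` gives 12900 nM
compound 2 `O=[N+]([O-])c1cccc(Nc2nc(SCc3ccc(C(F)(F)F)cc3)nc3ccccc23)c1` gives 13500 nM
compound 3 `O=[N+]([O-])c1ccc(Nc2nc(SCc3ccc(C(F)(F)F)cc3)nc3ccccc23)cc1` gives 7900 nM

In a functional assay on PC-3 cells (Homo sapiens) for cytotoxicity, read by MTT assay, with a stated time of 72 h (on this read-out higher numbers stand for weaker inhibition and lower numbers for stronger inhibition), the three measured compounds share one core and differ only in the ring on the anilino nitrogen. Compound 2 and compound 3 differ in how the same atoms are joined: 4-nitrophenyl in place of 3-nitrophenyl on a nitrogen on an aromatic ring, a step of a 1.7-fold lower number from compound 2 to compound 3 (0.23 log units; within the scatter). The change from compound 2 to compound 1 is trifluoromethyl in place of nitro on an aromatic carbon, and it gave a 1.0-fold lower number from compound 2 to compound 1 (0.02 log units; within the scatter).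

Compound 4 `FC(F)(F)c1ccc(CSc2nc(Nc3ccc(C(F)(F)F)cc3)c3ccccc3n2)cc1` has not yet been measured in this assay. It stands to compound 3 as compound 1 stands to compound 2: trifluoromethyl in place of nitro on an aromatic carbon. The place is not identical, since in compound 2 the group sits meta to a large group and in compound 3 para to a large group, so this is the same kind of change rather than the same change. Since the earlier step was a 1.0-fold lower number from compound 2 to compound 1 (0.02 log units; within the scatter), the step from compound 3 to compound 4 is expected to be about a 1.0-fold lower number from compound 3 to compound 4 (0.02 log units; within the scatter), resting on a single precedent. Compound 4 is therefore estimated at 7600 nM, between 3500 nM and 16500 nM.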

Compound 4, half-maximal inhibitory concentration: 7880 nM
Compound 4: middle estimate off by 1.0-fold (0.02 log units), on the low side, and the stated range covers the measured number.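

In this assay, trifluoromethyl in place of nitro, para to a large group, gave a 1.0-fold lower number from compound 3 to compound 4 (0.00 log units; within the scatter), and the other two new steps, a 1.7-fold lower number from compound 2 to compound 4 (0.23 log units; within the scatter) and a 1.6-fold lower number from compound 1 to compound 4 (0.21 log units; within the scatter), also stay inside the scatter. Within the data shown here, the change carried from one core to the other without a detectable difference: the same change on two cores in this assay, a 1.0-fold lower number (0.02 log units; within the scatter) from compound 2 to compound 1 and a 1.0-fold lower number (0.00 log units; within the scatter) from compound 3 to compound 4, 1.0-fold (0.02 log units) apart, within the scatter of two such steps This shows only that the exchange of these two groups left the number within the scatter in both pairs; since neither step is beyond the scatter, it does not show that a change with a real effect on one core would carry over to another, and it says nothing about why the two steps agree.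

The compounds shown leave open whether a nitrile, a methoxy group, an amine or a carboxylic acid on the anilino ring would move the number beyond the scatter. They also leave open whether the two steps would still agree in cells other than PC-3.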